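Sulfonamide aryl variation on a shared benzoxazole-bearing core

The source may hold more compounds than are shown below. What is called first, only, known or untested is meant among the compounds shown, and "the series" means these compounds.

Compound 3 `COc1ccc(Cl)cc1S(=O)(=O)Nc1ccc(-c2nc3ccccc3o2)cc1` stands at a limit, not at a number: in an assay on isolated protein for inhibition of malate dehydrogenase, mitochondrial (Sus scrofa), with stated times of 45 min and 30 min (on this read-out higher numbers stand for weaker inhibition and lower numbers for stronger inhibition), compound 3 gives > 63000 nM. Compound 1 `COc1ccccc1S(=O)(=O)Nc1ccc(-c2nc3ccccc3o2)cc1` likewise sits at a limit, giving > 63000 nM in this assay. Compound 2 `O=S(=O)(Nc1ccc(-c2nc3ccccc3o2)cc1)c1ccc(F)cc1` also sits at a limit and gives > 63000 nM in this assay. Every value shown so far rests on (the limit of > 63000 nM in this assay, at which 3 of the 3 values shown sit), so the three measured steps cannot be read: from compound 1 to compound 2 the step is a step that the two limits leave unreadable from compound 1 to compound 2, from compound 1 to compound 3 it is a step that the two limits leave unreadable from compound 1 to compound 3, and from compound 2 to compound 3 it is a step that the two limits leave unreadable from compound 2 to compound 3.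

Compound 4 `O=S(=O)(Nc1ccc(-c2nc3ccccc3o2)cc1)c1ccc(Cl)cc1` differs from compound 3 by 4-chlorophenyl in place of 5-chloro-2-methoxyphenyl on a sulfonyl sulfur. The closest measured steps bearing on this change are from compound 1 to compound 2 and from compound 2 to compound 3, both unreadable, and no aryl variation on the sulfonyl sulfur has so far moved any value off the limit. The step from compound 3 to compound 4 in this assay is therefore expected to be a step that the limit leaves unreadable from compound 3 to compound 4, that is, none beyond the scatter. For compound 4 the estimated value is 70000 nM, expected to fall between 30000 nM and 200000 nM, most probably again reported only as a limit.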

Compound 4, half-maximal inhibitory concentration: > 63000 nM
Compound 4: no number, only a limit; the forecaster's own chance of this, stated with the estimate: 85%; the middle value lies beyond the limit too.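

Compound 4 also stands at a limit in this assay, so none of its steps from compound 1, compound 2 and compound 3 can be read: the limit of > 63000 nM in this assay, at which 4 of the 4 values shown sit.

The compounds shown leave open whether any aryl group on the sulfonyl sulfur of the shared core gives a numerical value in this assay.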